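This account rests on a few compounds, and the source may have more. Where it says the series, first, only, none or still open, it means among the compounds named here.

In a functional assay on RS4-11 cells (Homo sapiens) for inhibition, read by CCK-8 assay, with a stated time of 48 h (a lower number here means a stronger inhibitor, a higher number a weaker inhibitor), compound 1 `Cc1ccc(-c2ccsc2S(=O)(=O)NCCNC(=O)Nc2cc(C(F)(F)F)cc(C(F)(F)F)c2)c(Oc2ccc(O)c(O)c2)c1` gives 5600 nM and compound 3 `O=C(Nc1ccc([N+](=O)[O-])cc1)N1CCN(S(=O)(=O)c2sccc2-c2ccccc2Oc2ccc(O)c(O)c2)CC1` gives 14300 nM. Compound 2 `COc1ccc(Oc2ccccc2-c2ccsc2S(=O)(=O)N2CCN(C(=O)Nc3ccc([N+](=O)[O-])cc3)CC2)cc1OC` reaches only a limit of this assay, > 50000 nM. The difference between the cores of compound 1 and compound 3 is not broken down here. Compound 2 arises from compound 3 by a single change, (3,4-dimethoxyphenyl in place of 3,4-dihydroxyphenyl on an oxygen on an aromatic ring), and this change gave an at least 3.4-fold higher number from compound 3 to compound 2 (0.54 log units; beyond the scatter), known only as a lower bound because of the limit of > 50000 nM in this assay, at which 1 of the 3 values shown sits. Compound 4 `COc1ccc(Oc2cc(C)ccc2-c2ccsc2S(=O)(=O)NCCNC(=O)Nc2cc(C(F)(F)F)cc(C(F)(F)F)c2)cc1OC` carries the same change made on compound 1, (3,4-dimethoxyphenyl in place of 3,4-dihydroxyphenyl on an oxygen on an aromatic ring). Because the measured step was an at least 3.4-fold higher number from compound 3 to compound 2 (0.54 log units; beyond the scatter), a weakening of similar or greater size is expected for compound 4, a 4.5-fold higher number from compound 1 to compound 4 (0.65 log units; beyond the scatter). Compound 4 is therefore estimated to give about 25000 nM, most likely between 10000 nM and 60000 nM, with a real chance that only a limit is reported.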

Compound 4, half-maximal inhibitory concentration: 5600 nM
Beside the measured number, compound 4's estimate is 4.5-fold (0.65 log units) above it; measured number outside the range, below it.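

In this assay, placing 3,4-dimethoxyphenyl where compound 1 carries 3,4-dihydroxyphenyl gave no change at the digits printed from compound 1 to compound 4 (within the scatter). The same change therefore did not carry the same result from one core to the other: the same change on two cores in this assay, an at least 3.4-fold higher number (0.54 log units; beyond the scatter) from compound 3 to compound 2 and no change at the digits printed (within the scatter) from compound 1 to compound 4, at least 3.4-fold (0.54 log units) apart, beyond the scatter of two such steps What this does not show is which part of the two cores decides the outcome, and the full size of the earlier step stays unknown, as compound 2 stands at a limit: the limit of > 50000 nM in this assay, at which 1 of the 4 values shown sits.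

The compounds shown leave open whether a phenyl ring bearing a single hydroxyl or a single methoxy, or one bearing a carboxylic acid, would behave alike on both cores.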